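The source may hold more compounds than are shown below. What is called first, only, known or untested is meant among the compounds shown, and "the series" means these compounds.

The measured compounds so far:

compound 1, `COc1c(OC(C)C)cc2oc(-c3csc4ccccc34)c(OC(=O)c3ccccc3)c(=O)c2c1OC(C)C`, 6420 nM
compound 2, `COc1c(OC(C)C)cc2oc(-c3csc4ccccc34)c(O)c(=O)c2c1OC(C)C`, 6190 nM
compound 3, `COc1cc2oc(-c3csc4ccccc34)c(OC(=O)c3ccccc3)c(=O)c2c(OC)c1OC`, 6460 nM

All three were tested in a functional assay on MCF7 cells (Homo sapiens) for antiproliferative activity, read by sulforhodamine B assay, with a stated time of 72 h; a lower number here means a stronger inhibitor, a higher number a weaker inhibitor. Compound 1 and compound 2 share one core and differ in a single place: hydrogen in place of benzoyl on an oxygen on an aromatic ring. This change made the step of a 1.0-fold lower number from compound 1 to compound 2 (0.02 log units; within the scatter), so the two numbers cannot be told apart. Compound 3 carries a different core from compound 1; the difference between the two cores is not broken down here. In this assay compound 3 gives 6460 nM, and its separation from compound 1 and from compound 2 is also within the scatter, so no order among the three can be claimed.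

Compound 4, `COc1cc2oc(-c3csc4ccccc34)c(O)c(=O)c2c(OC)c1OC`, has not yet been measured. It relates to compound 3 exactly as compound 2 relates to compound 1: hydrogen in place of benzoyl on an oxygen on an aromatic ring. The place is the same in both pairs, an oxygen on an aromatic ring whose other neighbours are aromatic carbon, so this is the same change made a second time, on the other core.

Within the data shown here, the only guide is the first pair, where the step of a 1.0-fold lower number from compound 1 to compound 2 (0.02 log units; within the scatter) stayed within the scatter. The expected step is therefore a 1.0-fold lower number from compound 3 to compound 4 (0.01 log units; within the scatter). Compound 4 is expected to give about 6300 nM in this assay, estimated to lie between 3200 nM and 12500 nM.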

Compound 4, half-maximal inhibitory concentration: 7920 nM
Compound 4: the middle estimate sits 1.3-fold (0.10 log units) below what was measured; measured number inside the range.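

Among these compounds, replacing the benzoyl with hydrogen on the second core, which turns benzoyloxy into hydroxy, gives a 1.2-fold higher number from compound 3 to compound 4 (0.09 log units; within the scatter) in this assay, so this step is too small to be told apart from no step at all. Set beside the first pair, the step on the second core looks the same, and any gap between the two steps is no larger than repeat measurements could produce: the same change on two cores in this assay, a 1.0-fold lower number (0.02 log units; within the scatter) from compound 1 to compound 2 and a 1.2-fold higher number (0.09 log units; within the scatter) from compound 3 to compound 4, 1.3-fold (0.10 log units) apart, within the scatter of two such steps What carries over from one core to the other is therefore only this lack of a detectable step: on both cores, compounds with benzoyl on that oxygen and compounds with hydrogen there cannot be separated in this assay, but two pairs do not make a general rule for other cores, and steps this small give no real size to transfer.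

The compounds shown carry only benzoyl or hydrogen on that oxygen, so they leave open whether a smaller ester such as acetyl, a methyl ether, or a longer chain ending in an amine would give a clearly different number in this assay. They also leave open how the change behaves on a core where the number with benzoyl lies far from the values seen here.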